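From cyclopentylamino to butylamino on the shared core

This account rests on a few compounds, and the source may have more. Where it says the series, first, only, none or still open, it means among the compounds named here.

In a functional assay on MCF7 cells (Homo sapiens) for inhibition, read by sulforhodamine B assay, with a stated time of 48 h (a lower number here means a stronger inhibitor of growth, a higher number a weaker inhibitor of growth), compound 3 `COc1ccc2c(c1)NC(=O)CN2c1nc(NC2CCCC2)nc2ccccc12` gives 7.67 nM and compound 1 `COc1ccc2c(c1)NC(=O)CN2c1nc(OCC2CC2)nc2ccccc12` gives 7.88 nM, with a 1.0-fold lower number from compound 1 to compound 3 (0.01 log units; within the scatter) showing the two level. Compound 2 `COc1ccc2c(c1)NC(=O)CN2c1nc(NCc2ccncc2)nc2ccccc12` gives 71.8 nM, and a 9.4-fold lower number from compound 2 to compound 3 (0.97 log units; beyond the scatter) places compound 3 well clear of it, as a 9.1-fold higher number from compound 1 to compound 2 (0.96 log units; beyond the scatter) does for compound 1. Compound 4 `CCCCNc1nc(N2CC(=O)Nc3cc(OC)ccc32)c2ccccc2n1` has butyl in place of cyclopentyl on a nitrogen on an aromatic ring. For the measured compounds named here, only a 9.4-fold lower number from compound 2 to compound 3 (0.97 log units; beyond the scatter) changes this same substituent, and no compound measured so far carries an open chain there, so the evidence is thin. A small estimated step is expected, a 1.4-fold higher number from compound 3 to compound 4 (0.16 log units; within the scatter), toward a slightly higher number and not beyond the scatter. Compound 4 is expected at 11 nM, with an estimated range of 4 nM to 35 nM.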

Compound 4, concentration for 50% growth inhibition in the MCF7 assay: 7.88 nM
Compound 4: the middle estimate sits 1.4-fold (0.14 log units) above what was measured, and the stated range covers the measured number.
By their numbers in the MCF7 assay, from the lowest: compounds 3, 1 and 4 (each within the scatter of the next); then compound 2.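

In the MCF7 assay this position takes an open chain as well as a ring: butyl in place of cyclopentyl gives a 1.0-fold higher number from compound 3 to compound 4 (0.01 log units; within the scatter), and butylamino in place of cyclopropylmethoxy gives no change at the digits printed from compound 1 to compound 4 (within the scatter), while compound 2 stays apart, with a 9.1-fold lower number from compound 2 to compound 4 (0.96 log units; beyond the scatter). The same change is far from silent in a physicochemical assay for lipophilicity, read by HPLC, measured as octanol-water partition, tested at 1 mg/mL (on this read-out higher numbers stand for higher lipophilicity and lower numbers for lower lipophilicity), where compound 3 gives 2.33 and compound 4 gives 3.91 so that across this pair growth inhibition does not follow the partition coefficient: the measured partition coefficient of compound 3, 2.33, and of compound 4, 3.91, a number 1.58 log units higher (beyond the scatter)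

On these data alone, whether a longer chain, or a chain carrying an amine, holds this level stays open. So does whether the pyridin-4-yl ring alone sets compound 2 apart.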